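Phenyl for methyl on compound 2: cytotoxicity outlook

The source may report more compounds than this note shows. Statements on the series, on what has been measured and on what is new or still open speak of the compounds shown alone.

Compound 2 `Cc1oc2c3c(ccc2c(=O)c1C)OC[C@H]1[C@@H]3C2=C(CC(C)(C)CC2=O)OC1(C)C` is one of three members of the series tested in an ADME assay on MRC5 cells (Homo sapiens) for antiproliferative activity, read by MTT assay, with a stated time of 48 h; a higher number here means a weaker inhibitor, a lower number a stronger inhibitor. In this assay compound 2 returns only a limit, > 100000 nM. Compound 1 `Cc1coc2c3c(ccc2c1=O)OC[C@H]1[C@@H]3C2=C(CCCC2=O)OC1(C)C` likewise gives a limit in this assay, > 100000 nM. Compound 3 `Cc1coc2c3c(ccc2c1=O)OC[C@H]1[C@@H]3C2=C(CC(C)(C)CC2=O)OC1(C)C` also gives a limit there, > 100000 nM. Within the data shown here, the single one-point step that can be drawn, a step that the two limits leave unreadable from compound 2 to compound 3, is unreadable because the limit of > 100000 nM in this assay, at which 3 of the 3 values shown sit, holds both of its ends.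

Compound 4 `Cc1oc2c3c(ccc2c(=O)c1-c1ccccc1)OC[C@H]1[C@@H]3C2=C(CC(C)(C)CC2=O)OC1(C)C` differs from compound 2 by phenyl in place of methyl on an aromatic carbon. Among the measured compounds shown here, no measured step bears on this change: the only step available, from compound 2 to compound 3, is a methyl removal and reads as nothing more than the limit.

With all three numbers at the limit, the step of a number no higher from compound 2 to compound 4 (the limit leaves the size open) is expected to be unresolved rather than a readable shift in either direction. Compound 4 is accordingly estimated at 100000 nM in this assay, with a range of 20000 nM to 300000 nM, most probably reported again as a limit.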

Compound 4, half-maximal inhibitory concentration: > 100000 nM
Compound 4: no number, only a limit (the forecaster's own chance of this, stated with the estimate: 80%); the middle value sits exactly at the limit.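

Compound 2 and compound 4 both sit at the limit in this assay, so no step can be read between them: the limit of > 100000 nM in this assay, at which 4 of the 4 values shown sit.

The compounds shown leave open what number any of them would return in this assay, and whether phenyl in place of methyl changes it at all.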